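The compounds below may be only part of what the source reports. "The series", "measured", "known", "first", "only" and "open" are said of these compounds alone.

In a functional assay on HepG2 cells (Homo sapiens) for antiproliferative activity, read by MTT assay, with a stated time of 72 h (a higher number here means a weaker inhibitor, a lower number a stronger inhibitor), compound 1, with the structure `NC1=NC2(CCSCC2)N(OCCCOc2cccc(Cl)c2)C(N)=N1`, gave 90 nM. Among the two compounds with a number in this assay, compound 1 stands at the lower end, but its gap to compound 2 (`NC1=NC2(CCOCC2)N(OCCCOc2cccc(Cl)c2)C(N)=N1`), which gave 150 nM, lies within the usual scatter, so the two cannot be ranked. Compound 3 (`NC1=NC2(CCOCC2)N(OCCCOc2ccc(F)cc2)C(N)=N1`) gave "not determined" (no result reported) in this assay, that is, no result is reported for it. Compound 4, with the structure `NC1=NC2(CCSCC2)N(OCCCOc2cccc(Cl)c2Cl)C(N)=N1`, has not yet been measured; it differs from compound 1 by chloro in place of hydrogen on an aromatic carbon. For the measured compounds named here, no measured pair shows the effect of this change, so the step from compound 1 to compound 4 is expected to be small, a 1.1-fold lower number from compound 1 to compound 4 (0.05 log units; within the scatter), with no clear direction beyond the scatter. Compound 4 is therefore estimated to give 80 nM, expected between 30 nM and 250 nM.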

Compound 4, half-maximal inhibitory concentration: 50 nM
Compound 4: the middle estimate sits 1.6-fold (0.20 log units) above what was measured, within the range that was stated.
By their numbers in this assay, from the lowest: compounds 4, 1 and 2 (each within the scatter of the next, the first and the last beyond it).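

In this assay, for the compounds shown here, this is the first measured case of a second chloro on this ring, placed ortho to the existing chloro group. Going from 3-chlorophenyl to 2,3-dichlorophenyl gives a 1.8-fold lower number from compound 1 to compound 4 (0.26 log units; within the scatter), a step that cannot be told apart from no change, so this ring carbon accepts a chloro with antiproliferative activity kept. Nothing measured here bears on what lies behind this result.

On these data alone, whether a methoxy group, an amine or a carboxylic acid at this same carbon would keep the activity remains open. So does whether this chloro would give a similar step on the core of compound 2.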